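Hydroxymethyl on the Methyl of a Sulfonamide: Cytotoxicity Outlook

A few compounds are considered here, and "the series" means these few. Any claim that something is new, unique, unknown or untested is made for them only; others in the source may bear on it.

Compound 1 `CCN(c1ccccc1)S(=O)(=O)c1cc(Cl)ccc1Cl` gives > 5000 nM in an ADME assay on A549 cells (Homo sapiens) for cytotoxicity, read by MTT assay; on this read-out lower numbers stand for higher toxicity in this test and higher numbers for lower toxicity in this test
Compound 2 `CCN(c1ccc(C)cc1)S(=O)(=O)c1cc(Cl)ccc1Cl` gives > 25000 nM in this assay

Both values are limits of this assay, not numbers. Compound 2 stands at a limit of > 25000 nM. Among the measured compounds shown here, the only measured step, a step that the two limits leave unreadable from compound 1 to compound 2, cannot be read in size for that reason. Compound 3 `CCN(c1ccc(CCO)cc1)S(=O)(=O)c1cc(Cl)ccc1Cl` carries hydroxymethyl in place of hydrogen on a saturated chain carbon bound to an aromatic carbon, a change on the group whose addition gave that unreadable step. For the measured compounds named here, no measured step therefore gives a direction beyond the scatter. Compound 3 is estimated at 30000 nM, between 10000 nM and 100000 nM, most likely again reported only as a limit. The expected step is a step that the limit leaves unreadable from compound 2 to compound 3.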

Compound 3, half-maximal cytotoxic concentration: > 25000 nM
Compound 3: a limit, no number (the forecaster's own chance of this, stated with the estimate: 80%); the middle value lies beyond the limit too.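

Among the compounds shown here, compound 1, compound 2 and compound 3 are all reported only as limits, not numbers, so no step between them can be read. As far as these compounds go, whether methyl or 2-hydroxyethyl changes the half-maximal cytotoxic concentration at all stays open.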